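A few compounds are considered here, and "the series" means these few. Any claim that something is new, unique, unknown or untested is made for them only; others in the source may bear on it.

Series notes. Within the data shown here, in a functional assay on HepG2 cells (Homo sapiens) for inhibition, read by MTT assay, with a stated time of 72 h (on this read-out lower numbers stand for stronger inhibition and higher numbers for weaker inhibition), compound 1 (`COc1ccc(-c2cc(C(=O)N3CCC4(CC3)CC(=O)c3nn(C(C)(C)C)cc3O4)c3ccccc3n2)cc1OC`) gives 1560 nM and compound 2 (`CC(C)(C)n1cc2c(n1)C(=O)CC1(CCN(C(=O)c3cc(-c4ccncc4)nc4ccccc34)CC1)O2`) gives 380 nM as the lower of the two numbers so far. Compound 3 (`CC(C)(C)n1cc2c(n1)C(=O)CC1(CCN(C(=O)c3cc(Cl)nc4ccccc34)CC1)O2`) is still unmeasured and differs from compound 2 by chloro in place of pyridin-4-yl on an aromatic carbon with chloro in place of pyridin-4-yl on an aromatic carbon. Among the measured compounds shown here, one measured step bears on this place: a 4.1-fold lower number from compound 1 to compound 2 (0.61 log units; beyond the scatter) on moving to pyridin-4-yl from 3,4-dimethoxyphenyl. For the measured compounds named here, that step exchanged one ring for another, whereas chloro brings no ring, and no measured compound carries chloro here, so the direction is uncertain. A modest rise in this assay is expected, toward compound 1 at 1560 nM as the only other measured point. The estimated change is a 3.2-fold higher number from compound 2 to compound 3 (0.50 log units; beyond the scatter) for now. For compound 3 the expected value is 1200 nM within a range of 400 nM to 4000 nM on present data.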

Compound 3, half-maximal inhibitory concentration: 4720 nM
The estimate for compound 3 lay 3.9-fold (0.59 log units) below the measured number, and the stated range ends below it.
By their numbers in this assay, from the lowest: compound 2; then compound 1; then compound 3.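

In this assay, among these compounds, the position is sensitive to losing the ring altogether: chloro in place of pyridin-4-yl gives a 12-fold higher number from compound 2 to compound 3 (1.09 log units; beyond the scatter), the largest step so far. Chloro in place of 3,4-dimethoxyphenyl also gives a 3.0-fold higher number from compound 1 to compound 3 (0.48 log units; beyond the scatter), so among these three compounds both ring-bearing groups give lower numbers than chloro, with no compound going against this. Nothing measured explains the difference between these groups at this place.

As far as these compounds go, it remains open whether an aromatic ring is needed here or whether a smaller non-ring group, such as an amine or a short alkyl chain, could match the ring-bearing compounds. From the compounds shown here alone, it is also open whether unsubstituted phenyl or a saturated ring such as morpholine would track with pyridin-4-yl or with 3,4-dimethoxyphenyl.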